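Estimating compound 4 from its 3-nitrophenyl neighbour

The source may report more compounds than this note shows. Statements on the series, on what has been measured and on what is new or still open speak of the compounds shown alone.

Measured in a physicochemical assay for lipophilicity; a lower number here means a more polar compound, a higher number a more lipophilic compound:
- Compound 1 `COc1cc(/C=C2\CCC/C(=C\c3ccccc3[N+](=O)[O-])C2=O)cc(OC)c1OC`: 4.33
- Compound 2 `O=C1/C(=C/c2ccc(F)cc2)CCC/C1=C\c1cccc([N+](=O)[O-])c1`: 5.07
- Compound 3 `COc1cc(/C=C2\CCC/C(=C\c3cccc([N+](=O)[O-])c3)C2=O)cc(OC)c1OC`: 4.53

In this assay compound 3 at 4.53 lies within the scatter of compound 1 at 4.33 and lower, beyond the scatter, than compound 2 at 5.07. Compound 4 `COc1cc(/C=C2\CCC/C(=C\c3ccc([N+](=O)[O-])cc3)C2=O)cc(OC)c1OC` has not yet been measured. It differs from compound 3 in one place, (4-nitrophenyl in place of 3-nitrophenyl on a double-bonded chain carbon bound to a double-bonded ring carbon), with 4-nitrophenyl in place of 3-nitrophenyl on a double-bonded chain carbon bound to a double-bonded ring carbon. For the measured compounds named here, only one measured step bears on this change. That step, a number 0.20 log units higher from compound 1 to compound 3 (within the scatter), exchanges 2-nitrophenyl for 3-nitrophenyl at the same place and stays within the scatter. A shift of the nitrophenyl group alone is therefore not expected to matter much here. The estimated step is a number 0.02 log units higher from compound 3 to compound 4 (within the scatter), which means no change beyond the scatter in either direction is expected. For compound 4 the estimated value is 4.55, with an expected range from 4.2 to 4.9.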

Compound 4, partition coefficient: 4.56
Estimate against measurement, compound 4: 0.01 log units below; low and high end bracket the measured number.
By their numbers in this assay, from the lowest: compounds 1, 3 and 4 (each within the scatter of the next); then compound 2.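

With compound 4, the nitrophenyl group has now been read in all three forms, 2-nitrophenyl, 3-nitrophenyl and 4-nitrophenyl, on a double-bonded chain carbon bound to a double-bonded ring carbon. In this assay the exchange of 3-nitrophenyl for 4-nitrophenyl gives a number 0.03 log units higher from compound 3 to compound 4 (within the scatter) and the exchange of 2-nitrophenyl for 4-nitrophenyl gives a number 0.23 log units higher from compound 1 to compound 4 (within the scatter) and so neither exchange separates the compounds. On the shared core of compounds 1, 3 and 4, moving the nitro group around the phenyl ring therefore makes no difference that this assay can resolve.

The compounds shown leave open whether a different group on that phenyl ring, such as an amine or a carboxylic acid, would also stay within the scatter. Nothing at hand speaks to why these three values lie together.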